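The source may report more compounds than this note shows. Statements on the series, on what has been measured and on what is new or still open speak of the compounds shown alone.

Measured compounds in a functional assay on L1210 cells (Mus musculus) for cytotoxicity, read by MTT assay, with a stated time of 48 h; a higher number here means a weaker inhibitor, a lower number a stronger inhibitor:

- compound 1 `C=C1C(=O)OC(C)CC1c1ccc([N+](=O)[O-])cc1` gives 1200 nM
- compound 2 `C=C1C(=O)OC(C)CC1c1ccc(Br)cc1` gives 1750 nM
- compound 3 `C=C1C(=O)O[C@H](C)[C@@H]1c1ccc([N+](=O)[O-])cc1` gives 1900 nM

All three values lie within the usual scatter of one another, so no order among the measured compounds is claimed here. One structural change appears twice in the series. Between compound 1 and compound 2 it is bromo in place of nitro on an aromatic carbon, and the step it made in this assay was a 1.5-fold higher number from compound 1 to compound 2 (0.16 log units; within the scatter). Compound 4 `C=C1C(=O)O[C@H](C)[C@@H]1c1ccc(Br)cc1` has not yet been measured; it differs from compound 3 by bromo in place of nitro on an aromatic carbon. The difference between the core of compound 1 and the core of compound 3 is not broken down here. The two places are not identical word for word: in compound 1 the aromatic carbon is para to a group of 9 heavy atoms, whereas in compound 3 it is para to a group of 8 heavy atoms, so the change from compound 3 to compound 4 is the same kind of change as that from compound 1 to compound 2, not the same change.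

The expectation for compound 4 rests on this single precedent. Because a 1.5-fold higher number from compound 1 to compound 2 (0.16 log units; within the scatter) lay within the scatter, the step in this assay from compound 3 to compound 4 is expected to be of similar size, namely a 1.5-fold higher number from compound 3 to compound 4 (0.17 log units; within the scatter). Compound 4 is accordingly estimated at 2800 nM, with an expected range from 1400 nM to 5600 nM. Within the data shown here, with only one prior instance of this kind of change, the uncertainty around this estimate is wide.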

Compound 4, half-maximal inhibitory concentration: 7800 nM
For compound 4 the middle estimate is 2.8-fold (0.44 log units) below the measured one; measured number above the stated range.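

In this assay, bromo in place of nitro on an aromatic carbon gave a 4.1-fold higher number from compound 3 to compound 4 (0.61 log units; beyond the scatter), and the size of this step does not carry over unchanged from one core to the other: the same change on two cores in this assay, a 1.5-fold higher number (0.16 log units; within the scatter) from compound 1 to compound 2 and a 4.1-fold higher number (0.61 log units; beyond the scatter) from compound 3 to compound 4, 2.8-fold (0.45 log units) apart, beyond the scatter of two such steps

Among these compounds, only the step on the core of compound 3 lies beyond the scatter, so the earlier step on the core of compound 1 gives no firm direction to carry across, and a step read on one of these cores is a poor guide to the step on the other. The comparison rests on a single pair of steps; it does not show which part of the difference between the two cores goes with the gap, nor how the same change would behave on any further core.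

Only nitro and bromo are shown on this aromatic carbon, so what an amine, a carboxylic acid or a methoxy group there would give on either core remains open. Also open, as far as these compounds go, is whether a longer chain in place of the methyl group on each core would alter either step.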